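Furan to Thiophene: One Swap on a Shared Core

The source may report more compounds than this note shows. Statements on the series, on what has been measured and on what is new or still open speak of the compounds shown alone.

Compound 1 `COc1ccc(-c2nc(NN)n(C)c(=O)c2C#N)cc1` gives 32 ug/mL.
Compound 2 `CSc1nc(-c2ccco2)c(C#N)c(=O)n1C` gives 79 ug/mL.
Compound 3 `CCOC(=O)c1cnn(-c2nc(-c3cccc(OC)c3OC)c(C#N)c(=O)n2C)c1N` gives 67 ug/mL.

In a functional assay, with a stated time of 10 min (on this read-out higher numbers stand for weaker inhibition and lower numbers for stronger inhibition), compound 2 stands highest of the three numbers. Its nearest neighbour is compound 3, whose value lies within the scatter of that of compound 2, while compound 1 sits furthest away, with a gap beyond the scatter. Compound 4 `CSc1nc(-c2cccs2)c(C#N)c(=O)n1C` has not yet been measured. It differs from compound 2 in one place: thiophen-2-yl in place of furan-2-yl on an aromatic carbon. No step between two measured compounds is known in this set, so the size of this change has no precedent among the numbers shown. One five-membered aromatic ring with 1 hetero atom gives way to another of the same count of heavy atoms, hydrogen-bond donors and hydrogen-bond acceptors, so in this assay a step no larger than the usual scatter is expected, in either direction. The step expected in this assay is a 1.1-fold lower number from compound 2 to compound 4 (0.05 log units; within the scatter). Compound 4 is therefore estimated at 70 ug/mL, with a range from 35 ug/mL to 140 ug/mL.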

Compound 4, half-maximal inhibitory concentration: 72 ug/mL
Estimate against measurement, compound 4: 1.0-fold (0.01 log units) below, within the range that was stated.
By their numbers in this assay, from the lowest: compound 1; then compounds 3, 4 and 2 (each within the scatter of the next).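

In this assay, among the compounds shown here, thiophen-2-yl in place of furan-2-yl gives the only single-place step on this shared core, a 1.1-fold lower number from compound 2 to compound 4 (0.04 log units; within the scatter), and that step lies within the usual scatter. On this aromatic carbon, ortho to a cyano group, the read-out therefore does not separate these two five-membered aromatic rings, one carrying oxygen and the other sulfur. Nothing measured here accounts for this result.

From the compounds shown here alone, whether the same holds for a pyridin-2-yl ring or an amine on this carbon stays open, as does the outcome of replacing the methylsulfanyl group with a longer chain. For the compounds shown here, no single-place step links compound 1 or compound 3 to compound 2 or compound 4, so the values of compound 1 and compound 3 cannot be assigned to any one group.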